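Removing one fluoro from the aryl group of compound 3

A few compounds are considered here, and "the series" means these few. Any claim that something is new, unique, unknown or untested is made for them only; others in the source may bear on it.

Compound 1, `C[C@H](Nc1ncnc2[nH]cnc12)c1nn(-c2cccnc2)c2cc(F)ccc12`: 23%
Compound 2, `C[C@H](Nc1ncnc2[nH]cnc12)c1nn(-c2ccccn2)c2cc(F)ccc12`: 22%
Compound 3, `C[C@H](Nc1ncnc2[nH]cnc12)c1nn(-c2cc(F)cc(F)c2)c2cc(F)ccc12`: 30%

In a functional assay on HepG2 cells (Homo sapiens) for inhibition, read by sulforhodamine B assay, with a stated time of 72 h, tested at 10 uM (a higher number here means more inhibition at the concentration tested (going by the name of the read-out), a lower number less inhibition), compound 3 gives the highest of the three numbers, yet every step to it lies within the scatter: a number 7 percentage points higher from compound 1 to compound 3 (within the scatter) and a number 8 percentage points higher from compound 2 to compound 3 (within the scatter). Compound 4, `C[C@H](Nc1ncnc2[nH]cnc12)c1nn(-c2cccc(F)c2)c2cc(F)ccc12`, differs from compound 3 by hydrogen in place of fluoro on an aromatic carbon. Going by the values given here, no measured step swaps a single fluoro for hydrogen, so the nearest guides are the aryl exchanges just named, both small. The step of a number 3 percentage points lower from compound 3 to compound 4 (within the scatter) is therefore expected to stay within the scatter. Compound 4 is estimated at 27%, with a range from 15% to 40%.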

Compound 4, a percentage reported as inhibition, at one concentration (the size of the read-out at that concentration, not a potency): 33%
Beside the measured number, compound 4's estimate is 6 percentage points below it; low and high end bracket the measured number.
By their numbers in this assay, from the lowest: compounds 2, 1, 3 and 4 (each within the scatter of the next, the first and the last beyond it).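

Going by these compounds alone, removing one fluoro from the 3,5-difluorophenyl group leaves the read-out within the scatter, with a number 3 percentage points higher from compound 3 to compound 4 (within the scatter) in this assay as the first direct reading of this change. Among the aryl exchanges, a number 11 percentage points higher from compound 2 to compound 4 (beyond the scatter) is the first to pass the scatter, though only modestly, while a number 10 percentage points higher from compound 1 to compound 4 (within the scatter) does not pass it. Nothing available accounts for these steps. From the compounds shown here alone, whether a methoxy group, an amine or a carboxylic acid on this aryl ring would shift the read-out stays open. Going by these compounds, each number also comes from one concentration, so potency stays open too.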